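A Second Methoxy Group on the Shared Core of Compound 1

The source may report more compounds than this note shows. Statements on the series, on what has been measured and on what is new or still open speak of the compounds shown alone.

Of the compounds shown here, two have so far been tested in a functional assay on M14 cells (Homo sapiens) for cytotoxicity, read by sulforhodamine B assay, with a stated time of 48 h, tested at 1 uM; on this read-out higher numbers stand for a weaker effect at the one concentration tested and lower numbers for a stronger effect. Compound 1, `COc1ccc(-c2cc(/C=C/C(=O)c3ccc(N)cc3)[nH]n2)cc1`, gives 105% in this assay, the higher of the two numbers recorded and therefore the weaker effect at the single concentration used. Compound 2, `COc1cc(-c2cc(/C=C/C(=O)c3ccc(F)c(F)c3)[nH]n2)cc(OC)c1OC`, gives 86% in this assay, a lower number that lies beyond the usual scatter.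

Compound 3, `COc1ccc(-c2cc(/C=C/C(=O)c3ccc(N)cc3)[nH]n2)cc1OC`, has not yet been measured. It differs from compound 1 in one place: methoxy in place of hydrogen on an aromatic carbon. Among the measured compounds shown here, no pair of measured compounds differs in a single place, so the size of such a step cannot be read from the numbers in hand. The step of a number 5 percentage points lower from compound 1 to compound 3 (within the scatter) is expected to be small, not beyond the scatter. Compound 3 is therefore estimated to give 100% in this assay, within a range of 84% to 114%.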

Compound 3, a percentage reported as activity, at one concentration (the size of the read-out at that concentration, not a potency): 101%
Estimate against measurement, compound 3: 1 percentage points below, and the stated range covers the measured number.
By their numbers in this assay, from the lowest: compound 2; then compounds 3 and 1 (each within the scatter of the next).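

Methoxy in place of hydrogen on an aromatic carbon, ortho to a methoxy group and meta to a large group, gives a number 4 percentage points lower from compound 1 to compound 3 (within the scatter) in this assay. Among the compounds shown here, this is the first single-place step available, and it shows that adding methoxy at this position leaves compound 3 indistinguishable from compound 1 at the one concentration tested, which the earlier compounds, differing from each other in more than one place, could not show. Nothing at hand offers an explanation for this outcome.

Going by these compounds, whether a hydroxyl group, an amine or a longer chain such as ethoxy at this position would produce a step beyond the scatter remains open. For the compounds shown here, compound 2 differs from compound 3 in more than one place, so no step between them can be read.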